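This account rests on a few compounds, and the source may have more. Where it says the series, first, only, none or still open, it means among the compounds named here.

Working notes on the series, measured in an ADME assay on microsomes from liver (Homo sapiens) for metabolic stability, read by LC-MS, using NADPH, with stated times of 10 min and 30 min; on this read-out lower numbers stand for slow clearance and higher numbers for fast clearance:
- Compound 1 (`CC[C@@H]1c2cc(Cl)ccc2C(=O)N1c1cncc2c1CCC[C@H]2NC(C)=O`): < 3.5 mL/min/kg (a limit)
- Compound 2 (`CCC(=O)N[C@@H]1CCCc2c1cncc2N1C(=O)c2ccc(Cl)cc2[C@@H]1CC`): < 3.5 mL/min/kg (a limit)
- Compound 3 (`CCC(=O)N[C@@H]1CCCc2c1cncc2N1Cc2cc(Cl)ccc2C1=O`): < 3.5 mL/min/kg (a limit)

Compound 2 gives < 3.5 mL/min/kg as a limit of the assay and not a number, so it has no exact place in the series. Among the measured compounds shown here, the same holds for every compound so far, which all sit at one boundary (the limit of < 3.5 mL/min/kg in this assay, at which 3 of the 3 values shown sit).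

The next step leads to compound 4 (`CC[C@H]1c2cc(Cl)ccc2C(=O)N1c1cncc2c1CCC[C@H]2NC(C)=O`). The change is hydrogen in place of methyl on a saturated chain carbon bound to a carbonyl carbon and, cut one bond further out, it reads propanoyl to acetyl.

For the measured compounds named here, only one measured step is available (a step that the two limits leave unreadable from compound 2 to compound 3). It lies at a different place in the molecule from this change, and its size cannot be read, so it gives no measure for the present step. The data therefore hold no size to carry over.

In this assay no step beyond the scatter is expected, and the estimated step (a step that the limit leaves unreadable from compound 2 to compound 4) is read in that sense. This expectation rests on compound 2 at < 3.5 mL/min/kg as a limit, with the change confined to the propanoyl chain.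

For compound 4 the estimated value is 3 mL/min/kg with an expected range from 1.5 mL/min/kg to 6 mL/min/kg and a report of the limit alone is the likeliest outcome.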

Compound 4, clearance: < 3.5 mL/min/kg
Compound 4 was reported as a limit; the forecaster's own chance of this, stated with the estimate: 80%; the middle value is on the limit's open side.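

In this assay compound 4 gives < 3.5 mL/min/kg as a limit and not a number, so no new step can be read from compound 4 to compound 2 or compound 1: the limit of < 3.5 mL/min/kg in this assay, at which 4 of the 4 values shown sit.

The compounds shown leave open whether propanoyl to acetyl or the drawn configuration changes clearance at all, the latter being the sole difference in one pair: the fact that compounds 1 and 4 differ only in the configuration as drawn.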